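Changing the Aryl Group on the Triazole: Dimethyl to Dichloro

The source may hold more compounds than are shown below. What is called first, only, known or untested is meant among the compounds shown, and "the series" means these compounds.

Measured compounds:
Compound 1 `CCc1ccccc1-n1nncc1CN1C(=O)C2(C(C#N)=C(N)Oc3c(N)cc4nc5ccccc5nc4c32)c2ccccc21`: in a functional assay on A549 cells (Homo sapiens) for antiproliferative activity, read by MTT assay, with a stated time of 48 h (a lower number here means a stronger inhibitor, a higher number a weaker inhibitor), compound 1 gives 24600 nM.
Compound 2 `CC(=O)Nc1ccc(-n2nncc2CN2C(=O)C3(C(C#N)=C(N)Oc4c(N)cc5nc6ccccc6nc5c43)c3ccccc32)cc1`: in this assay compound 2 reaches only a limit of the assay, > 50000 nM, not a number.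
Compound 3 `Cc1ccc(C)c(-n2nncc2CN2C(=O)C3(C(C#N)=C(N)Oc4c(N)cc5nc6ccccc6nc5c43)c3ccccc32)c1`: in this assay compound 3 likewise reaches only a limit, > 50000 nM.

Compound 3 therefore stands at the edge of what this assay can report, and it shares that position: the limit of > 50000 nM in this assay, at which 2 of the 3 values shown sit. Only compound 1 returns a number. The step from compound 1 is recorded as an at least 2.0-fold higher number from compound 1 to compound 3 (0.30 log units; that floor lies within the scatter), so its true size is open. The step between the two limits is a step that the two limits leave unreadable from compound 2 to compound 3.

Compound 4 `N#CC1=C(N)Oc2c(N)cc3nc4ccccc4nc3c2C12C(=O)N(Cc1cnnn1-c1ccc(Cl)cc1Cl)c1ccccc12` differs from compound 3 in one place: 2,4-dichlorophenyl in place of 2,5-dimethylphenyl on an aromatic nitrogen. For the measured compounds named here, no measured compound carries the 2,4-dichlorophenyl group, and the two steps that touch this position give no readable size. There is thus no ground for expecting compound 4 to move clearly in either direction beyond the scatter.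

Compound 4 is expected to give about 45000 nM in this assay, between 15000 nM and 120000 nM. The step this estimate implies is an at least 1.1-fold lower number from compound 3 to compound 4 (0.04 log units; that floor lies within the scatter).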

Compound 4, half-maximal inhibitory concentration: > 50000 nM
Compound 4 gave a limit, no number; the forecaster's own chance of this, stated with the estimate: 55%; middle value at least 1.1-fold (0.04 log units) away from the limit.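

With 2,4-dichlorophenyl on the aromatic nitrogen, compound 4 joins compound 2 and compound 3, so three quite different aryl groups at this position now return no number: the limit of > 50000 nM in this assay, at which 3 of the 4 values shown sit. For the compounds shown here, replacing two methyl groups with two chlorine atoms, whose places on the ring also differ, therefore does not bring a readable value, and this holds for a group with no carbon-only substituents, which the earlier compounds did not show. On these data alone, only compound 1, with 2-ethylphenyl, still gives a number, and the record against it is an at least 2.0-fold higher number from compound 1 to compound 4 (0.30 log units; that floor lies within the scatter), so the true size of that step stays open, while the steps to compound 4 from compound 2 and from compound 3 cannot be read.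

The compounds shown leave open whether any aryl group at this position can give a value clearly apart from that of compound 1, for instance a phenyl ring carrying an amine or a carboxylic acid, or one with a chain longer than ethyl. They also leave open how far beyond the limit compound 2, compound 3 and compound 4 truly lie, and whether they differ from one another at all.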